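Methyl to Chloro on the Outer Aromatic Ring: Compound 3

This account rests on a few compounds, and the source may have more. Where it says the series, first, only, none or still open, it means among the compounds named here.

Compound 1 `O=C(O)C[C@@H]1CCCN1c1ccc(Oc2ccccc2)cc1`: 560 nM
Compound 2 `Cc1cccc(Oc2ccc(N3CCC[C@H]3CC(=O)O)cc2)c1`: 260 nM

In a functional assay on cells for agonist activity at Free fatty acid receptor 1 (Homo sapiens), read by FLIPR and calcium flux, with a stated time of 100 s (on this read-out lower numbers stand for an effect already at smaller amounts and higher numbers for an effect only at larger amounts of compound), compound 1 gives 560 nM and compound 2 gives 260 nM. Among the compounds with values here, compound 2 thus holds the lowest of the two numbers measured so far, with compound 1 as its nearest neighbour. Within the data shown here, the single measured step, a 2.2-fold lower number from compound 1 to compound 2 (0.33 log units; beyond the scatter), shows that placing a methyl group on the outer aromatic ring lowers the number by a modest amount that just clears the usual scatter.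

Compound 3 `O=C(O)C[C@@H]1CCCN1c1ccc(Oc2cccc(Cl)c2)cc1` differs from compound 2 by the change (chloro in place of methyl on an aromatic carbon). Among the measured compounds shown here, no measured step covers the exchange of a methyl group for a chloro group; the one step available only shows what a methyl group adds relative to hydrogen. With the substituent kept at the same place and of the same size in heavy atoms, the step of a 1.2-fold lower number from compound 2 to compound 3 (0.07 log units; within the scatter) is expected to stay within the scatter. The value for compound 3 is estimated at 220 nM, in a range from 80 nM to 600 nM.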

Compound 3, half-maximal effective concentration: 680 nM
Compound 3: the middle estimate sits 3.1-fold (0.49 log units) below what was measured; the whole stated range lies below it.
By their numbers in this assay, from the lowest: compound 2; then compounds 1 and 3 (each within the scatter of the next).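

On an aromatic carbon meta to a large group, methyl and chloro are not interchangeable in this assay, even though each adds one heavy atom (a 2.6-fold higher number from compound 2 to compound 3 (0.42 log units; beyond the scatter)). The lower number that methyl gave over hydrogen does not carry over to chloro, since compound 3 cannot be told apart from compound 1, which has hydrogen at this place (a 1.2-fold higher number from compound 1 to compound 3 (0.08 log units; within the scatter)). Nothing available here accounts for this difference between methyl and chloro.

On these data alone, whether a methoxy or an ethyl group at this same place would give a number nearer that of compound 2 or that of compound 3 remains open. The compounds shown also carry their substituent at only this one place, so what methyl or chloro would do elsewhere on the outer ring is unknown.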